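The source may report more compounds than this note shows. Statements on the series, on what has been measured and on what is new or still open speak of the compounds shown alone.

Compound 1 `N#CC1=C(N)Oc2c(c3nc4ccccc4nc3c3ccccc23)C12C(=O)N(Cc1cnnn1-c1ccc(F)cc1)c1ccccc12` belongs to a small set of three analogues that share one core and differ only in the aryl group carried on the triazole nitrogen. In an ADME assay on L02 cells (Homo sapiens) for antiproliferative activity, read by MTT assay, with a stated time of 48 h (a higher number here means a weaker inhibitor, a lower number a stronger inhibitor), compound 1 gives > 50000 nM, which is a limit of the assay rather than a number. Compound 2 `N#CC1=C(N)Oc2c(c3nc4ccccc4nc3c3ccccc23)C12C(=O)N(Cc1cnnn1-c1ccc(Cl)cc1)c1ccccc12` likewise gives > 50000 nM in this assay, again a limit. Compound 3 `N#CC1=C(N)Oc2c(c3nc4ccccc4nc3c3ccccc23)C12C(=O)N(Cc1cnnn1-c1cccc(Cl)c1)c1ccccc12` gives 35200 nM in this assay. The step that the two limits leave unreadable from compound 1 to compound 2 therefore cannot be read, while an at least 1.4-fold lower number from compound 1 to compound 3 (0.15 log units; that floor lies within the scatter) and an at least 1.4-fold lower number from compound 2 to compound 3 (0.15 log units; that floor lies within the scatter) are each only a floor, and the limit of > 50000 nM in this assay, at which 2 of the 3 values shown sit, marks where two of the three values sit. Compound 4 `N#CC1=C(N)Oc2c(c3nc4ccccc4nc3c3ccccc23)C12C(=O)N(Cc1cnnn1-c1ccccc1Br)c1ccccc12` is not yet measured; it differs from compound 1 by 2-bromophenyl in place of 4-fluorophenyl on an aromatic nitrogen. The two readable steps both bear on this move, since each replaces the aryl group on the same nitrogen, and neither exceeds the scatter in any readable way. No more than a small shift is therefore expected, and a further limit is quite possible. Compound 4 is expected to give about 45000 nM in this assay, estimated between 25000 nM and 70000 nM. This means an expected step of an at least 1.1-fold lower number from compound 1 to compound 4 (0.04 log units; that floor lies within the scatter).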

Compound 4, half-maximal inhibitory concentration: > 50000 nM
Compound 4: a limit, no number (the forecaster's own chance of this, stated with the estimate: 55%); middle value at least 1.1-fold (0.04 log units) away from the limit.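

In this assay, compound 4 adds a 2-bromophenyl group to the aryl groups on the triazole nitrogen that give no number, and its value is a limit of the assay: the limit of > 50000 nM in this assay, at which 3 of the 4 values shown sit. The steps from compound 1 and from compound 2 to compound 4 cannot be read, since both ends of each are limits. The only step here with a floor is an at least 1.4-fold higher number from compound 3 to compound 4 (0.15 log units; that floor lies within the scatter), so moving to a bromine on the 2-position of the phenyl ring does not separate compound 4 from compound 3 by any readable margin, and compound 3 remains the only one of the four with a number, without being shown to stand beyond the scatter from the others.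

The compounds leave open how far compounds 1, 2 and 4 lie past that limit, and so whether the aryl group on this nitrogen changes the read-out at all. They also leave open what this assay would give with a plain phenyl, a 4-methoxyphenyl, a phenyl carrying an amine or a carboxylic acid, or a short alkyl chain on the same nitrogen.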